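Fluoro in Place of Hydrogen, Seen Once, Expected Again

A few compounds are considered here, and "the series" means these few. Any claim that something is new, unique, unknown or untested is made for them only; others in the source may bear on it.

The account begins with compound 1, `Fc1cc(Cl)ccc1-c1ccc(Cn2nnc3ccccc32)cn1`. In an ADME assay on microsomes from liver (Mus musculus, strain NMRI) for metabolic stability, tested at 2.5 uM (on this read-out lower numbers stand for slow clearance and higher numbers for fast clearance), compound 1 gives 3.4 mL/min/g. Compound 2, `Fc1ccc2nnn(Cc3ccc(-c4ccc(Cl)cc4F)nc3)c2c1`, differs from it by fluoro in place of hydrogen on an aromatic carbon, and in this assay compound 2 gives 2.2 mL/min/g, which is a 1.5-fold lower number from compound 1 to compound 2 (0.19 log units; within the scatter).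

Compound 3, `Brc1cccc2c1nnn2Cc1ccccc1`, has a different core; how its core differs from that of compound 1 is not broken down here. In this assay compound 3 gives 2.3 mL/min/g. Its value lies within the scatter of both compound 1 and compound 2, so nothing can be said about order among the three.

Compound 4, `Fc1ccc(Cn2nnc3c(Br)cccc32)cc1`, has not yet been measured. It differs from compound 3 by fluoro in place of hydrogen on an aromatic carbon. Going by the values given here, this is the same kind of change as the one from compound 1 to compound 2, though the surroundings are not identical: in compound 2 the fluoro sits on a ring that is part of a fused or bridged system of two rings, meta to a fused ring and para to a fused ring, whereas in compound 4 it sits on a ring of carbon only, para to a large group.

Because a 1.5-fold lower number from compound 1 to compound 2 (0.19 log units; within the scatter) stayed within the scatter, the step from compound 3 to compound 4 in this assay is expected to be a 1.2-fold lower number from compound 3 to compound 4 (0.06 log units; within the scatter). Compound 4 is therefore estimated at 2 mL/min/g, with a plausible range from 1 mL/min/g to 4 mL/min/g.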

Compound 4, intrinsic clearance in a liver preparation (reported as CLH), per the amount of preparation that the assay uses: 1 mL/min/g
The estimate for compound 4 lay 2.0-fold (0.30 log units) above the measured number; the range from low to high includes it.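

In this assay, the swap of fluoro for hydrogen on an aromatic carbon gave a 2.3-fold lower number from compound 3 to compound 4 (0.36 log units; beyond the scatter), so on this second core the step, though modest, stands clear of the usual scatter, as the earlier step did not. Set side by side, the two steps run in the same direction and cannot be told apart in size: the same change on two cores in this assay, a 1.5-fold lower number (0.19 log units; within the scatter) from compound 1 to compound 2 and a 2.3-fold lower number (0.36 log units; beyond the scatter) from compound 3 to compound 4, 1.5-fold (0.17 log units) apart, within the scatter of two such steps. This supports carrying the change from one core to the other as a step that lowers the number or leaves it within the scatter, but it does not show that the step is larger on the core of compound 3, and two pairs, one of them within the scatter, make no rule for the series as a whole.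

The compounds shown leave open whether a nitrile, a methoxy group or an amine in place of the same hydrogen would move the number in the same direction as fluoro does. Going by these compounds alone, they also leave open whether the fluoro step would hold on a third core, or at another position on the ring of carbon only that carries it in compound 4.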